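A few compounds are considered here, and "the series" means these few. Any claim that something is new, unique, unknown or untested is made for them only; others in the source may bear on it.

In an ADME assay on Vero cells (Chlorocebus sabaeus) for cytotoxicity, with a stated time of 5 days (on this read-out higher numbers stand for weaker inhibition and lower numbers for stronger inhibition), compound 1 `CNc1nc(Cl)nc2c1ncn2[C@H]1C[C@H](N=[N+]=[N-])[C@@H](CO)O1` gives > 100000 nM as a limit of the assay and not a number. Going by the values given here, compound 2 `[N-]=[N+]=N[C@H]1C[C@H](n2cnc3c(Cl)nc(F)nc32)O[C@@H]1CO` gives 21800 nM in this assay and so carries the only true number so far, with nothing exact to rank it against.

Compound 3 `[N-]=[N+]=N[C@H]1C[C@H](n2cnc3c(N)nc(F)nc32)O[C@@H]1CO` is built from compound 2 by one small edit, (amino in place of chloro on an aromatic carbon), which puts amino in place of chloro on an aromatic carbon. The rest of the molecule stays the same.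

Among the compounds with values here, no measured step shows what this kind of swap does, so any expectation here is a loose one. Within the data shown here, compound 2 at 21800 nM is the sole number to start from. Compound 1 offers only a limit of the assay. A moderate move in this assay toward higher numbers, meaning weaker inhibition, is therefore expected, although a result within the scatter would be no surprise. The expected change is a 2.5-fold higher number from compound 2 to compound 3 (0.40 log units; beyond the scatter) in this estimate. For compound 3 the estimated value is 55000 nM, with an expected range from 15000 nM to 100000 nM.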

Compound 3, half-maximal inhibitory concentration: 34400 nM
Compound 3: middle estimate off by 1.6-fold (0.20 log units), on the high side, within the range that was stated.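

Going by these compounds alone, this is the first single-place step in the set: in this assay, putting amino in place of chloro on an aromatic carbon, next to the ring nitrogen and ortho to a fused ring, gives a 1.6-fold higher number from compound 2 to compound 3 (0.20 log units; within the scatter). At this position, with the fluoro group and the rest of the molecule kept as they are, the swap therefore stays inside the usual scatter of the assay, even though amino brings a hydrogen-bond donor and a hydrogen-bond acceptor that chloro does not have. Compound 1 holds only a limit of the assay and not a number, and no single-place step connects it to the other compounds, so it adds nothing exact to this picture: the limit of > 100000 nM in this assay, at which 1 of the 3 values shown sits.

Still open, going by these compounds, is whether other groups at this same position, such as methoxy, bromo or a cyclopropylamine, would also stay within the scatter or would move the result clearly in either direction. Also open, on these data alone, is whether the swap from chloro to amino would give a similar step if a methyl group stood in place of the fluoro group, since a single step cannot establish a general rule.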